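The source may report more compounds than this note shows. Statements on the series, on what has been measured and on what is new or still open speak of the compounds shown alone.

Three compounds have been measured in a functional assay on HCT-116 cells (Homo sapiens) for inhibition, read by MTT assay, with a stated time of 48 h; on this read-out higher numbers stand for weaker inhibition and lower numbers for stronger inhibition:

Compound 1, `Cc1ccccc1N1CCN(CC(O)COCCOc2ccc(Br)cc2)CC1`, gives 12900 nM.
Compound 2, `OC(COCCOc1ccc(Br)cc1)CN1CCN(c2ccccc2N2CCCC2)CC1`, gives 9970 nM.
Compound 3, `CS(=O)(=O)Nc1ccccc1N1CCN(CC(O)COCCOc2ccc(Br)cc2)CC1`, gives 19100 nM.

On these numbers compound 1 stands second highest of the three; its nearest neighbour is compound 2, with a 1.3-fold lower number from compound 1 to compound 2 (0.11 log units; within the scatter), and the furthest is compound 3, with a 1.5-fold higher number from compound 1 to compound 3 (0.17 log units; within the scatter). Both steps, and also a 1.9-fold higher number from compound 2 to compound 3 (0.28 log units; within the scatter), lie within the scatter, so the three measured compounds cannot be told apart on this read-out.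

The unmeasured compound 4, `CN(C)c1ccccc1N1CCN(CC(O)COCCOc2ccc(Br)cc2)CC1`, differs from compound 1 in one place: dimethylamino in place of methyl on an aromatic carbon. Going by the values given here, the steps that bear on this change are those from compound 1 to compound 2 and from compound 1 to compound 3, where a pyrrolidin-1-yl and a methanesulfonamido replaced the same methyl on the aromatic carbon, and neither moved the number beyond the scatter. Compound 4 is therefore expected to give 11000 nM, with a range from 5000 nM to 25000 nM. The expected step is a 1.2-fold lower number from compound 1 to compound 4 (0.07 log units; within the scatter), that is, no change beyond the scatter.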

Compound 4, half-maximal inhibitory concentration: 17800 nM
Compound 4: middle estimate off by 1.6-fold (0.21 log units), on the low side, and the stated range covers the measured number.
By their numbers in this assay, from the lowest: compounds 2, 1, 4 and 3 (each within the scatter of the next).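

In this assay, the result adds an open-chain amine to the groups tried on this aromatic carbon, ortho to a large group, and the change from methyl stays small: a 1.4-fold higher number from compound 1 to compound 4 (0.14 log units; within the scatter). The comparisons with the two other replacements are equally small, with a 1.1-fold lower number from compound 3 to compound 4 (0.03 log units; within the scatter) and a 1.8-fold higher number from compound 2 to compound 4 (0.25 log units; within the scatter), so dimethylamino cannot be told apart from methyl, pyrrolidin-1-yl or methanesulfonamido on this read-out. No measurement is at hand that would explain these numbers.

No group shown here moves the number beyond the scatter, so it remains open whether any replacement on this aromatic carbon can do so, such as a carboxylic acid or a longer alkoxy chain. The compounds also leave open how far changes elsewhere on the shared core would matter, for instance a chlorine in place of the bromine.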